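From 3-Bromophenyl to 4-Cyanophenyl on the Amide Nitrogen

This account rests on a few compounds, and the source may have more. Where it says the series, first, only, none or still open, it means among the compounds named here.

In a functional assay on A549 cells (Homo sapiens) for inhibition, read by MTT assay, with a stated time of 72 h (a higher number here means a weaker inhibitor, a lower number a stronger inhibitor), compound 1 `CCCc1ccc(NC(=O)C2CCN(C/C=C/c3ccccc3)CC2)cc1` gives 9470 nM as its half-maximal inhibitory concentration, compound 2 `CCCCCc1ccc(NC(=O)C2CCN(C/C=C/c3ccccc3)CC2)cc1` gives 3880 nM and compound 3 `O=C(Nc1cccc(Br)c1)C1CCN(C/C=C/c2ccccc2)CC1` gives 16500 nM on the same read-out. Compound 3 therefore stands clearly apart from compound 2 only, and cannot be told from compound 1.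

Compound 4 `N#Cc1ccc(NC(=O)C2CCN(C/C=C/c3ccccc3)CC2)cc1` keeps the shared core but carries 4-cyanophenyl in place of 3-bromophenyl on an amide-type nitrogen in the comparison with compound 3. Among the measured compounds shown here, no measured step makes this exact swap. The closest guide is the exchange of one substituted phenyl for another, which gave a 1.7-fold higher number from compound 1 to compound 3 (0.24 log units; within the scatter) and so stayed small. Lengthening the chain gave a 2.4-fold lower number from compound 1 to compound 2 (0.39 log units; beyond the scatter) but that is a different kind of change, and it was modest.

So in this assay no shift beyond the scatter is expected. The expected step is a 1.2-fold lower number from compound 3 to compound 4 (0.07 log units; within the scatter) for this swap. Compound 4 is estimated at 14000 nM within an expected range of 6000 nM to 32000 nM on this read-out.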

Compound 4, half-maximal inhibitory concentration: 40200 nM
Compound 4: the middle estimate sits 2.9-fold (0.46 log units) below what was measured, outside the stated range (above it).
By their numbers in this assay, from the lowest: compound 2; then compounds 1 and 3 (each within the scatter of the next); then compound 4.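

Exchanging one substituted phenyl for another on the amide-type nitrogen need not be a quiet change in this assay: the earlier exchange stayed within the scatter, but 4-cyanophenyl in place of 3-bromophenyl gives a 2.4-fold higher number from compound 3 to compound 4 (0.39 log units; beyond the scatter) and lies beyond it. Cyano in place of an alkyl chain on the aromatic carbon also matters, with a 4.2-fold higher number from compound 1 to compound 4 (0.63 log units; beyond the scatter) when propyl leaves and a 10-fold higher number from compound 2 to compound 4 (1.02 log units; beyond the scatter) when pentyl leaves, so compound 4 has the highest number of the four. Nothing measured here explains this result.

The compounds shown leave open whether the number keeps falling with a chain longer than pentyl, and how an amine or a carboxylic acid would read in place of cyano. They also cannot separate the group from its place on the ring, as 3-bromophenyl and 4-cyanophenyl differ in both.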